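Chain shortening on the hydroxy core: compound 2 to compound 3

A few compounds are considered here, and "the series" means these few. Any claim that something is new, unique, unknown or untested is made for them only; others in the source may bear on it.

The two measured compounds do not share a single-point change, so only their values stand side by side. Compound 1 `CCCCCCc1cc2cn(COCCO)c(=O)nc2o1` reports a limit in a functional assay on HEL cells (Homo sapiens) (a higher number here means that more compound is tolerated, a lower number that less compound is tolerated), > 200000 nM, and no number. Among the compounds with values here, compound 2 `CCCCCCCCCCc1cc2cn(COCCO)c(O)nc-2n1` gives 32000 nM in this assay, the only number among the values shown. The other value shown, that of compound 1, is a limit (the limit of > 200000 nM in this assay, at which 1 of the 2 values shown sits). Compound 3 `CCCCc1cc2cn(COCCO)c(O)nc-2n1` is not yet measured in this assay and differs from compound 2 by hydrogen in place of hexyl on a saturated chain carbon, four bonds along the chain from an aromatic carbon.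

Within the data shown here, no measured step is available to scale the expected change. From the decyl chain of compound 2 to the butyl chain, an upward shift in this assay is expected, and the step of a 4.1-fold higher number from compound 2 to compound 3 (0.61 log units; beyond the scatter) is estimated as beyond the usual scatter. Compound 3 is expected to give about 130000 nM in this assay, within a range from 40000 nM to 400000 nM, with a real chance that only a limit is reported.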

Compound 3, half-maximal cytotoxic concentration: > 200000 nM
Compound 3 ended at the assay's limit (the forecaster's own chance of this, stated with the estimate: 40%); middle value at least 1.5-fold (0.18 log units) from the limit.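

Within the data shown here, this is the first single-point step: on the shared core, hydrogen in place of hexyl on a saturated chain carbon, four bonds along the chain from an aromatic carbon, gives an at least 6.2-fold higher number from compound 2 to compound 3 (0.79 log units; beyond the scatter) in this assay. Shortening the chain at this position on this core therefore moves the read-out beyond the scatter, with less compound tolerated for the longer-chain compound 2. The size of the step is only a lower bound, since the value of compound 3 is a limit and not a number: the limit of > 200000 nM in this assay, at which 2 of the 3 values shown sit.

Where along the chain the change sets in stays open, and an octyl chain on the same core would help place it, while a dodecyl chain would test the long end. Compound 1 differs from the other two in more than one place, so the contribution of the core cannot be read.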